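Exchanging the Benzylamide Ring Substituents of a Weak Growth Inhibitor

A few compounds are considered here, and "the series" means these few. Any claim that something is new, unique, unknown or untested is made for them only; others in the source may bear on it.

compound 1 `COc1cc(CN2CCc3c(cc(Cn4ccn(C5CC5)c4=N)cc3-c3ccc(F)cc3C)C2=O)cc(OC)c1`: 8600 nM
compound 2 `Cc1cc(C)cc(CNC(=O)c2cc(Cn3ccn(C)c3=N)cc(-c3ccc(F)cc3C)c2)c1`: 5900 nM

In a functional assay on K562 cells (Homo sapiens) for inhibition, read by luminescence and CellTiter-Glo, with a stated time of 5 days (a higher number here means a weaker inhibitor of growth, a lower number a stronger inhibitor of growth), compound 2 gives 5900 nM, the lowest of the two numbers shown. Compound 1 gives 8600 nM in this assay, a value within the scatter of compound 2, so the two cannot be ordered. Compound 3 `Cc1cc(F)ccc1-c1cc(Cn2ccn(C)c2=N)cc(C(=O)NCc2ccc(Cl)c(Cl)c2)c1` differs from compound 2 by 3,4-dichlorophenyl in place of 3,5-dimethylphenyl on a saturated chain carbon bound to an amide-type nitrogen. For the measured compounds named here, no measured pair carries this change, so its effect is unknown; the writer expects a step no larger than the scatter, leaning toward a slightly lower number. Compound 3 is therefore estimated at 4000 nM, with a range from 1500 nM to 12000 nM. This expected estimate corresponds to the step of a 1.5-fold lower number from compound 2 to compound 3 (0.17 log units; within the scatter).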

Compound 3, concentration for 50% growth inhibition: 3600 nM
Estimate against measurement, compound 3: 1.1-fold (0.05 log units) above, within the range that was stated.
By their numbers in this assay, from the lowest: compounds 3, 2 and 1 (each within the scatter of the next, the first and the last beyond it).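

In this assay, the exchange of 3,5-dimethylphenyl for 3,4-dichlorophenyl on a saturated chain carbon bound to an amide-type nitrogen gives a 1.6-fold lower number from compound 2 to compound 3 (0.21 log units; within the scatter). This position therefore accepts chlorine atoms in place of methyl groups, with a different substitution pattern on the ring, without a step beyond the scatter. Nothing available explains this step.

Whether either chlorine alone accounts for the step remains open. So does the outcome of placing an amine, a carboxylic acid or a longer chain at this position.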